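Wheat growth inhibition: chain extension on two hydroxamate ester cores

The source may hold more compounds than are shown below. What is called first, only, known or untested is meant among the compounds shown, and "the series" means these compounds.

Measured so far:
- compound 1, `CCC(=O)ON1C(=O)COc2ccc(F)cc21`, 81900 nM
- compound 2, `CCC(=O)ON1C(=O)COc2c(Cl)cccc21`, 1300000 nM
- compound 3, `CCCCC(=O)ON1C(=O)COc2ccc(F)cc21`, 58200 nM

All three were run in an ADME assay on the whole organism for inhibition, with Triticum aestivum as the target, with a stated time of 5 days; on this read-out lower numbers stand for stronger inhibition and higher numbers for weaker inhibition. Compound 2 carries the highest number of the three; against compound 1 it is higher by a margin beyond the scatter, and against compound 3 by a still wider one. The difference between the core of compound 1 and the core of compound 2 is not broken down here.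

Going by the values given here, the one change measured as a single step is ethyl in place of hydrogen on a saturated chain carbon, two bonds along the chain from a carbonyl carbon. It gives a 1.4-fold lower number from compound 1 to compound 3 (0.15 log units; within the scatter), a step that stays within the scatter, so compounds 1 and 3 are not separated by this assay.

Compound 4, `CCCCC(=O)ON1C(=O)COc2c(Cl)cccc21`, is not yet measured. It stands to compound 2 as compound 3 stands to compound 1: the change is ethyl in place of hydrogen on a saturated chain carbon, two bonds along the chain from a carbonyl carbon, the same change at the same place. Among the compounds with values here, with only one measured instance of it, and that instance within the scatter, the expectation for compound 4 in this assay is a step of about the same size, a 1.3-fold lower number from compound 2 to compound 4 (0.11 log units; within the scatter), and the high number of compound 2, 1300000 nM, is expected to remain roughly where it is. The estimate for compound 4 is 1000000 nM, expected to fall between 400000 nM and 2500000 nM.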

Compound 4, half-maximal inhibitory concentration: 1640000 nM
Estimate against measurement, compound 4: 1.6-fold (0.21 log units) below, and the stated range covers the measured number.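

In this assay, ethyl in place of hydrogen on a saturated chain carbon, two bonds along the chain from a carbonyl carbon, gives a 1.3-fold higher number from compound 2 to compound 4 (0.10 log units; within the scatter), so this pair is not separated by the read-out and the chain extension leaves the core of compound 2 with a number as high as before. Set beside the same change on the core of compound 1, the step does not differ between the two cores: the same change on two cores in this assay, a 1.4-fold lower number (0.15 log units; within the scatter) from compound 1 to compound 3 and a 1.3-fold higher number (0.10 log units; within the scatter) from compound 2 to compound 4, 1.8-fold (0.25 log units) apart, within the scatter of two such steps. Going by these compounds alone, this shows that, going from propanoyl to butylcarbonyl, the change carries across these two cores as a step too small to read, but it does not show that any real effect of the change is transferred, as neither step rises beyond the scatter and only two cores are represented.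

The compounds shown leave open whether a longer chain, a branched chain or a chain ending in a carboxylic acid or an amine would move the number on either core. They also leave open how the difference between the core of compound 1 and the core of compound 2 divides into single changes, for instance through a core carrying chlorine where the core of compound 1 carries fluorine, or one carrying neither halogen.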